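From a pyrazole to a thiazole on the amide side chain

A few compounds are considered here, and "the series" means these few. Any claim that something is new, unique, unknown or untested is made for them only; others in the source may bear on it.

Compound 1 `CCN(Cc1cc[nH]n1)C(=O)COc1ccc(C)cc1` was tested in an assay on HEK293 cells for agonist activity at transient receptor potential cation channel subfamily M member 8 (Homo sapiens), read by fluorescence and calcium flux, with a stated time of 15 min (a higher number here means that more compound is needed for the effect, a lower number that less compound is needed), and recorded as "not active" (no number reported); no single number stands for it, so its position can be given only as not active. A related compound, compound 2 `CCN(Cc1cccs1)C(=O)COc1ccc(C(F)(F)F)cc1`, carries a different five-membered ring and a trifluoromethyl group on the phenyl ring, and in this assay compound 2 gives 236 nM. Compound 3 `CCN(Cc1cncs1)C(=O)COc1ccc(C)cc1` keeps the core of compound 1 and changes only the ring on the saturated chain carbon bound to an amide-type nitrogen: 1,3-thiazol-5-yl in place of 1H-pyrazol-3-yl on a saturated chain carbon bound to an amide-type nitrogen. For the measured compounds named here, no step between measured compounds shows what this exchange alone does. Going by the values given here, since compound 1 has no number, the step to compound 3 cannot be sized; what can be said is that compound 3 is the only compound here that shares the methyl-bearing phenyl ring of compound 1 while moving toward a ring without a hydrogen-bond donor, closer in kind to that of compound 2. The expectation is therefore that compound 3 shows measurable but weak activity, estimated at 2000 nM with a range from 400 nM to 20000 nM, with a real chance that only a limit is reported.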

Compound 3, half-maximal effective concentration: 1100 nM
Estimate against measurement, compound 3: 1.8-fold (0.26 log units) above; the range from low to high includes it.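

In this assay, for the compounds shown here, compound 1 is recorded as "not active" (no number reported) without a number, so no step to compound 3 can be read. The compounds shown leave open how much the exchange of 1H-pyrazol-3-yl for 1,3-thiazol-5-yl contributes on its own. No measurement here offers an explanation for the result.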